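Trimming One Carbon from the Chain of Compound 1

The source may hold more compounds than are shown below. What is called first, only, known or untested is meant among the compounds shown, and "the series" means these compounds.

Compound 1 `CCCCCCCCCCCCS(=O)(=O)/C=C/c1ccc(O)c(O)c1` sits second highest of three numbers, though all three lie within the scatter of one another: in a functional assay, read by fluorescence and spectrophotometry, with a stated time of 1 h (on this read-out lower numbers stand for an effect already at smaller amounts and higher numbers for an effect only at larger amounts of compound), compound 1 gives 8500 nM. Compound 2 `O=S(=O)(/C=C/c1ccc(O)c(O)c1)CC1CCCC1` gives 9400 nM, and compound 3 `CCCCCCS(=O)(=O)/C=C/c1ccc(O)c(O)c1` gives 7300 nM. Compound 4 `CCCCCCCCCCCS(=O)(=O)/C=C/c1ccc(O)c(O)c1` differs from compound 1 by hydrogen in place of methyl on a saturated chain carbon, ten or more bonds along the chain from a sulfonyl sulfur. For the measured compounds named here, the steps that bear on this are a 1.2-fold lower number from compound 1 to compound 3 (0.07 log units; within the scatter), which removes a far longer piece of the same chain, and a 1.3-fold lower number from compound 2 to compound 3 (0.11 log units; within the scatter); neither moved beyond the scatter. Because a much larger shortening left a 1.2-fold lower number from compound 1 to compound 3 (0.07 log units; within the scatter) flat, compound 4 is expected to show no change at the digits printed from compound 1 to compound 4 (within the scatter). Compound 4 is therefore estimated at 8500 nM, with a range of 4500 nM to 16000 nM.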

Compound 4, half-maximal effective concentration: 11400 nM
Estimate against measurement, compound 4: 1.3-fold (0.13 log units) below; measured number inside the range.
By their numbers in this assay, from the lowest: compounds 3, 1, 2 and 4 (each within the scatter of the next).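

Compound 4 shows that hydrogen in place of methyl on a saturated chain carbon gives a 1.3-fold higher number from compound 1 to compound 4 (0.13 log units; within the scatter) in this assay. Pentyl in place of hydrogen on a saturated chain carbon, six bonds along the chain from a sulfonyl sulfur, gives a 1.6-fold higher number from compound 3 to compound 4 (0.19 log units; within the scatter), so neither the small nor the large change in this chain leaves the scatter.

From the compounds shown here alone, whether a carboxylic acid or an amine at the chain end, or a chain longer than that of compound 1, would move the number beyond the scatter remains open. No independent measurement is available to explain these numbers.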